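Changing the Sulfide Side-Chain of a Weakly Cytotoxic Core

This account rests on a few compounds, and the source may have more. Where it says the series, first, only, none or still open, it means among the compounds named here.

Compound 1 `Cc1nnc(SCc2ccccc2Cl)n1N1C(=O)c2ccccc2C1=O` in a functional assay on A549 cells (Homo sapiens) for cytotoxicity, read by MTT assay, with a stated time of 48 h (on this read-out lower numbers stand for stronger inhibition and higher numbers for weaker inhibition), reaches only the assay limit > 200000 nM.
Compound 2 `COc1cc(-c2nnc(SCc3ccccc3Cl)n2N2C(=O)c3ccccc3C2=O)cc(OC)c1OC` in this assay likewise reaches only the limit > 200000 nM.

Compound 2 therefore stands at the limit of this assay, with no number of its own; both values shown sit at the same limit (the limit of > 200000 nM in this assay, at which 2 of the 2 values shown sit). Among the measured compounds shown here, the single measured step, a step that the two limits leave unreadable from compound 1 to compound 2, cannot be read. Both of its ends are limits rather than numbers, so it gives no guide to how any change in this series moves the read-out.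

Compound 3 `COc1cc(-c2nnc(SCC(=O)c3ccc(F)c(F)c3)n2N2C(=O)c3ccccc3C2=O)cc(OC)c1OC` keeps the shared core of compound 2 and differs only in the sulfide side-chain: (3,4-difluorophenyl)carbonyl in place of 2-chlorophenyl on a saturated chain carbon bound to a sulfur. For the measured compounds named here, no measured step bears on this particular change, and the one step that exists is unreadable, so there is no basis to expect a shift beyond the scatter in either direction. Compound 3 is thus expected to remain near the limit, estimated at 200000 nM with a range from 60000 nM to 400000 nM. The expected step is a number no higher from compound 2 to compound 3 (the limit leaves the size open), most likely again reported only as a limit.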

Compound 3, half-maximal inhibitory concentration: > 200000 nM
Compound 3: no number, only a limit (the forecaster's own chance of this, stated with the estimate: 70%); the middle value lies on the limit itself.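

Compound 3 gives only a limit, as do compound 1 and compound 2, so neither the step to compound 2 nor the step to compound 3 can be read. These compounds leave open whether any change on the shared core would give a real number in this assay at all, since every value so far is a limit: the limit of > 200000 nM in this assay, at which 3 of the 3 values shown sit.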